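Working notes on buffer stability in the series

A few compounds are considered here, and "the series" means these few. Any claim that something is new, unique, unknown or untested is made for them only; others in the source may bear on it.

Measured so far:
compound 1 `C[C@@H](O)[C@H]1C(=O)N2C(C(=O)OCOC(=O)C(C)(C)C)=C(S[C@@H]3CN[C@H](C(=O)Nc4cccc(C(=O)OCOC(=O)C(C)(C)C)c4)C3)[C@H](C)[C@H]12`: in a physicochemical assay for metabolic stability, read by LC-MS, in phosphate buffer, with a stated time of 3 h, at pH 7.4, tested at 50 uM (on this read-out higher numbers stand for a more stable compound and lower numbers for a less stable compound), compound 1 gives > 95%, a limit of the assay.
compound 2 `C[C@@H](O)[C@H]1C(=O)N2C(C(=O)OCOC(=O)C(C)(C)C)=C(S[C@@H]3CN[C@H](C(=O)Nc4cccc(C(=O)O)c4)C3)[C@H](C)[C@H]12`: in this assay compound 2 gives > 95%, likewise a limit.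
compound 3 `C[C@@H](O)[C@H]1C(=O)N2C(C(=O)O)=C(S[C@@H]3CN[C@H](C(=O)Nc4cccc(C(=O)OCC(F)(F)F)c4)C3)[C@H](C)[C@H]12`: in this assay compound 3 gives > 95%, again only a limit.

Where compound 2 stands: its result in this assay is a limit, not a number, and it sits with the rest of the set, because of the limit of > 95% in this assay, at which 3 of the 3 values shown sit. For the measured compounds named here, the one single-point change that has been measured, a step that the two limits leave unreadable from compound 1 to compound 2, cannot be read in size for the same reason: both ends are limits.

Compound 4 `CC(C)OC(=O)OCOC(=O)C1=C(S[C@@H]2CN[C@H](C(=O)Nc3cccc(C(=O)O)c3)C2)[C@H](C)[C@@H]2[C@@H]([C@@H](C)O)C(=O)N12` differs from compound 2 by isopropoxy in place of tert-butyl on a carbonyl carbon.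

Going by the values given here, no measured step bears on this change in a readable way, since the only single-point step, from compound 1 to compound 2, is hidden by the limits. Among the compounds with values here, what the set does show is that every compound so far, whichever ester or acid it carries, reaches the limit in this assay. Compound 4 is therefore expected to do the same, with a step that the limit leaves unreadable from compound 2 to compound 4 that is expected to stay within the scatter. The estimate for compound 4 in this assay is 97%, between 88% and 100%, most likely reported again as a limit.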

Compound 4, percent of the compound remaining: > 95%
Compound 4 was reported as a limit; the forecaster's own chance of this, stated with the estimate: 85%; the middle value lies beyond the limit too.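

No new step can be read: compound 2 and compound 4 both give limits rather than numbers, so the change from tert-butyl to isopropoxy on a carbonyl carbon has no readable size, because both sit at the same limit: the limit of > 95% in this assay, at which 4 of the 4 values shown sit.

The compounds shown leave open whether any difference among them alters the percent remaining in this assay.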